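Renal carcinoma growth inhibition: halogen pattern on the anilino ring

The compounds below may be only part of what the source reports. "The series", "measured", "known", "first", "only" and "open" are said of these compounds alone.

Measured compounds:
- compound 1, `CN1CCN(CCCOc2cccc3nc(Nc4ccc(Cl)c(F)c4)ccc23)CC1`: 6210 nM
- compound 2, `CN1CCN(CCCOc2cccc3nc(Nc4ccc(F)c(F)c4)ccc23)CC1`: 8980 nM

Both compounds share one core and differ only in the halogens on the phenyl group attached to the amine nitrogen. In a functional assay on cells (Panel renal (Carcinoma cell lines), Homo sapiens) for inhibition, read by sulforhodamine B assay, with a stated time of 48 h (a higher number here means a weaker inhibitor of growth, a lower number a stronger inhibitor of growth), compound 1 gives 6210 nM and compound 2 gives 8980 nM. For the measured compounds named here, the single step, a 1.4-fold higher number from compound 1 to compound 2 (0.16 log units; within the scatter), is within the scatter, so the two compounds stand together and neither can be called the stronger.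

Compound 3, `CN1CCN(CCCOc2cccc3nc(Nc4cc(Cl)cc(Cl)c4)ccc23)CC1`, has not yet been measured in this assay. Its change from compound 2 is 3,5-dichlorophenyl in place of 3,4-difluorophenyl on a nitrogen on an aromatic ring. Going by the values given here, only the step from compound 1 to compound 2 bears on this change, and only in part: it swaps one halogen for another at a fixed position, and it reads as no change beyond the scatter. Among the compounds with values here, the shift of the halogen pattern to 3,5-dichlorophenyl has no measured counterpart here, so the direction of any effect is unknown.

Compound 3 is therefore expected to stay near compound 2, with a step of a 1.3-fold lower number from compound 2 to compound 3 (0.11 log units; within the scatter) at most, and its estimated value is 7000 nM, in a range from 2500 nM to 20000 nM.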

Compound 3, concentration for total growth inhibition: 5560 nM
Beside the measured number, compound 3's estimate is 1.3-fold (0.10 log units) above it; low and high end bracket the measured number.
By their numbers in this assay, from the lowest: compounds 3, 1 and 2 (each within the scatter of the next).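

In this assay, the earlier pair covered only one halogen exchanged for another, whereas 3,5-dichlorophenyl on a nitrogen on an aromatic ring changes both the halogens and their arrangement. In place of 3,4-difluorophenyl it gives a 1.6-fold lower number from compound 2 to compound 3 (0.21 log units; within the scatter), and in place of 4-chloro-3-fluorophenyl it gives a 1.1-fold lower number from compound 1 to compound 3 (0.05 log units; within the scatter). The three dihalogenated phenyl groups at this place therefore cannot be separated in this assay, even with the arrangement of the halogens changed, and no supporting data are available to explain this flat reading.

On these data alone, all three compounds carry two halogens on the phenyl group, so it remains open whether an unsubstituted phenyl, or a phenyl bearing a methoxy group, an amine or a carboxylic acid, would read beyond the scatter from these three. As far as these compounds go, it also remains open whether a change elsewhere, such as a longer chain between the shared core and the terminal methylpiperazine, would separate compounds that the halogen changes do not.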